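The source may report more compounds than this note shows. Statements on the series, on what has been measured and on what is new or still open speak of the compounds shown alone.

Of the compounds shown here, two have so far been measured in a functional assay on HepG2 cells (Homo sapiens) for antiproliferative activity, read by MTT assay, with a stated time of 48 h; a higher number here means a weaker inhibitor, a lower number a stronger inhibitor. Compound 1 `CCCCCCOc1ccc(C(=O)/C=C/c2c(/C=C/c3ccc(OC)cc3)cc(OC)cc2OC)cc1` gives 16.2 ug/mL in this assay. Compound 2 `COc1ccc(/C=C/c2cc(OC)cc(OC)c2/C=C/C(=O)c2ccccc2C)cc1` gives 5.3 ug/mL in this assay, the lower of the two numbers, and its gap to compound 1 lies beyond the usual scatter. Compound 3 `COc1ccc(/C=C/c2cc(OC)cc(OC)c2/C=C/C(=O)c2ccc(Cl)cc2)cc1` has not yet been measured. It differs from compound 2 in one place: 4-chlorophenyl in place of 2-methylphenyl on a carbonyl carbon. For the measured compounds named here, no measured pair carries this change, so its effect is not known here; the single comparison at hand, compound 1 against compound 2, concerns a different part of the molecule. With nothing to fix a direction, the step of a 1.0-fold higher number from compound 2 to compound 3 (0.02 log units; within the scatter) is expected to remain within the scatter, in either direction. Compound 3 is accordingly estimated at 5.5 ug/mL, with a range from 2.2 ug/mL to 14 ug/mL wide enough to allow a moderate shift either way.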

Compound 3, half-maximal inhibitory concentration: 13.6 ug/mL
For compound 3 the middle estimate is 2.5-fold (0.39 log units) below the measured one; the range from low to high includes it.
By their numbers in this assay, from the lowest: compound 2; then compounds 3 and 1 (each within the scatter of the next).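

In this assay, the group on the carbonyl carbon now has a measured effect: 4-chlorophenyl in place of 2-methylphenyl gives a step beyond the scatter (a 2.6-fold higher number from compound 2 to compound 3 (0.41 log units; beyond the scatter)). Chloro in place of hexyloxy on an aromatic carbon, by contrast, stays within the scatter (a 1.2-fold lower number from compound 1 to compound 3 (0.08 log units; within the scatter)), so this read-out does not separate these two groups. No available data bear on the cause of either step.

Because 2-methylphenyl and 4-chlorophenyl differ in both the substituent and its place on the ring, the compounds shown do not tell which of the two carries the step. Unsubstituted phenyl, 4-methylphenyl and 2-chlorophenyl on the same carbonyl carbon would separate these two factors, while the effect of an amine on that ring remains open.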